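The source may hold more compounds than are shown below. What is called first, only, known or untested is meant among the compounds shown, and "the series" means these compounds.

Measured in a functional assay on brain (Rattus norvegicus, strain Wistar) for inhibition; on this read-out lower numbers stand for stronger inhibition and higher numbers for weaker inhibition:
- compound 1 `CCCCOc1ccc(-c2c(C)[nH]c(=O)n2C)cc1`: 5100 nM
- compound 2 `COc1ccc(-c2c(C)[nH]c(=O)n2C)cc1`: 147000 nM
- compound 3 `CCCCCCCOc1ccc(-c2c(C)[nH]c(=O)n2C)cc1`: 5700 nM

Compound 3 cannot be told apart from compound 1, with a 1.1-fold higher number from compound 1 to compound 3 (0.05 log units; within the scatter). Compound 2 stands well clear of this pair, with a 26-fold lower number from compound 2 to compound 3 (1.41 log units; beyond the scatter).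

Next is compound 4 `Cc1[nH]c(=O)n(C)c1-c1ccc(OCc2ccccc2)cc1`, which carries this change: phenyl in place of hexyl on a saturated chain carbon bound to an oxygen on an aromatic ring. In words, phenyl in place of hexyl on a saturated chain carbon bound to an oxygen on an aromatic ring. Cut one bond further out, the same difference reads heptyl to benzyl.

Going by the values given here, two measured steps bear on this. Removing the propyl gave a large step, a 29-fold higher number from compound 1 to compound 2 (1.46 log units; beyond the scatter), so the number responds strongly to whether anything is carried on this carbon. Adding propyl further along the chain gave a 1.1-fold higher number from compound 1 to compound 3 (0.05 log units; within the scatter), so the extra chain made no measurable difference. Compound 4 keeps a six-carbon group at the same place, which favours a number near those of compound 1 and compound 3. Among the compounds with values here, no measured compound carries a ring there, so the direct evidence is thin and the range stays wide.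

The expectation is no change beyond the scatter, with an estimated 1.1-fold higher number from compound 3 to compound 4 (0.02 log units; within the scatter). In this assay the estimated value for compound 4 is 6000 nM, with an expected range of 1800 nM to 20000 nM.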

Compound 4, half-maximal inhibitory concentration: 6700 nM
Beside the measured number, compound 4's estimate is 1.1-fold (0.05 log units) below it, within the range that was stated.
By their numbers in this assay, from the lowest: compounds 1, 3 and 4 (each within the scatter of the next); then compound 2.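

In this assay, an aromatic ring is tolerated at this place, on a saturated chain carbon bound to an oxygen on an aromatic ring: phenyl in place of hexyl, each of 6 heavy atoms, gives a 1.2-fold higher number from compound 3 to compound 4 (0.07 log units; within the scatter), and phenyl in place of propyl gives a 1.3-fold higher number from compound 1 to compound 4 (0.12 log units; within the scatter). The large step from hydrogen is therefore not confined to saturated chains, since phenyl in place of hydrogen gives a 22-fold lower number from compound 2 to compound 4 (1.34 log units; beyond the scatter). Across the compounds shown, the presence of a group on this carbon separates the numbers, whereas ring versus chain does not. No supporting measurement bears on why the ring and the chains cannot be told apart here.

From the compounds shown here alone, it remains open whether the tolerance extends to a phenyl carrying an amine or a carboxylic acid, or to a chain longer than heptyl. Going by these compounds, it is also open whether methyl or ethyl on this carbon would already give numbers like those of the larger groups, or would stay closer to the number of compound 2.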